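The source may hold more compounds than are shown below. What is called first, only, known or untested is meant among the compounds shown, and "the series" means these compounds.

Four compounds share one core and differ in a single group. In a physicochemical assay for lipophilicity, using the shake flask method, in phosphate buffer, measured as octanol-water partition, with a stated time of 24 h, at pH 7.4, tested at 100 uM (a lower number here means a more polar compound, a higher number a more lipophilic compound), only compound 2 (`Cc1cc(O)cc(C)c1-c1cccc(COc2ccc(OCC(=O)O)c(F)c2)c1`) has a number, 2.37. Compound 1 (`Cc1cc(OC(C)C)cc(C)c1-c1cccc(COc2ccc(OCC(=O)O)c(F)c2)c1`) gives "not determined" (no result reported), and compound 3 (`Cc1cc(OCc2ccccc2)cc(C)c1-c1cccc(COc2ccc(OCC(=O)O)c(F)c2)c1`) gives "not determined" (no result reported), so compound 3 offers no number to start from. Compound 4 (`COc1cc(C)c(-c2cccc(COc3ccc(OCC(=O)O)c(F)c3)c2)c(C)c1`) differs from compound 3 as follows: hydrogen in place of phenyl on a saturated chain carbon bound to an oxygen on an aromatic ring. This puts hydrogen in place of phenyl on a saturated chain carbon bound to an oxygen on an aromatic ring, turning benzyloxy into methoxy. Going by the values given here, no measured step exists as a guide, but a fall well beyond the usual scatter is expected in this assay on going from compound 3 to compound 4. Among the compounds with values here, the only numerical anchor is compound 2, at 2.37. The expected value for compound 4 is 2.9, with an estimated range from 2.4 to 3.4.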

Compound 4, distribution coefficient: 3.2
Beside the measured number, compound 4's estimate is 0.30 log units below it; the range from low to high includes it.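

In this assay, the oxygen on the aromatic ring now has its first measured change: methyl in place of hydrogen there gives a number 0.83 log units higher from compound 2 to compound 4 (beyond the scatter). So a single methyl on this oxygen is enough to move the number clearly. No measurement at hand explains the size of this step.

Steps involving compound 1 and compound 3 cannot be read, since neither compound has a number. On these data alone, what a longer chain or a chain ending in an amine would do on this oxygen remains open.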